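Swapping an Acetamidopyridine for an Aminoindazole

The source may hold more compounds than are shown below. What is called first, only, known or untested is meant among the compounds shown, and "the series" means these compounds.

Three compounds have been measured so far:
Compound 1, `CC(C)(C)OC(=O)N1C[C@@H](n2cc(-c3ccc(N)nc3)nn2)C[C@H]1C(=O)Nc1ccc(Cl)c(C(F)(F)F)c1`: 48.6%
Compound 2, `CC(=O)Nc1ccc(-c2cn([C@@H]3CN[C@H](C(=O)Nc4ccc(Cl)c(C(F)(F)F)c4)C3)nn2)cn1`: 33.6%
Compound 3, `CC(C)(C)OC(=O)N1C[C@@H](n2cc(-c3ccc4c(N)n[nH]c4c3)nn2)C[C@H]1C(=O)Nc1ccc(Br)cc1`: 23%

All three were tested in a functional assay on K562/Adr cells (Homo sapiens) for inhibition, read by MTT assay, with a stated time of 48 h, tested at 30 uM; a lower number here means less inhibition, a higher number more inhibition at the concentration tested (going by the name of the read-out). Compound 2 gives 33.6% and stands second highest of the three numbers. Its nearest neighbour is compound 3, whose value is lower by a margin beyond the usual scatter, and the furthest is compound 1, whose value is higher, again beyond the scatter. Compound 2 shares the free ring nitrogen of its core with none of the others, and shares the chloro-trifluoromethyl-substituted amide with compound 1 only, so the numbers do not separate the effect of either feature.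

The next compound to be measured is compound 4, `Nc1n[nH]c2cc(-c3cn([C@@H]4CN[C@H](C(=O)Nc5ccc(Cl)c(C(F)(F)F)c5)C4)nn3)ccc12`. It differs from compound 2 in one place: 3-amino-1H-indazol-6-yl in place of 6-acetamidopyridin-3-yl on an aromatic carbon. Among the compounds with values here, compound 3 already carries the entering group, though on a different core and with a different amide, and gives the lowest value of the three, while no direct step isolates this change. The step from compound 2 to compound 4 is therefore expected to be small, at most a slight decrease, a number 3.6 percentage points lower from compound 2 to compound 4 (within the scatter), lying within the scatter. Compound 4 is estimated to give 30%, with a range from 15% to 45%.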

Compound 4, a percentage reported as inhibition, at one concentration (the size of the read-out at that concentration, not a potency): 48.2%
The estimate for compound 4 lay 18.2 percentage points below the measured number; the whole stated range lies below it.
By their numbers in this assay, from the lowest: compound 3; then compound 2; then compounds 4 and 1 (each within the scatter of the next).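

Exchanging 6-acetamidopyridin-3-yl for 3-amino-1H-indazol-6-yl, on an aromatic carbon of the five-membered aromatic ring with 3 nitrogen, gives a number 14.6 percentage points higher from compound 2 to compound 4 (beyond the scatter) in this assay, so with the rest of the molecule held fixed, the group at this position changes the read-out. Within the data shown here, compound 3 carries the same 3-amino-1H-indazol-6-yl but differs from compound 4 in more than one place, so only the step to compound 4 isolates this group. Nothing measured here explains the step.

The exchange replaces the acetamide and the ring system at once, so the compounds shown leave open which of these changes matters, and a 1H-indazol-6-yl without the amino group or a 6-aminopyridin-3-yl on the core of compound 2 would help to separate them. Also open, from the compounds shown here alone, is how a simple phenyl group or a carboxylic acid would behave at this position, and since each number is the inhibition at a single concentration, the step says nothing about potency.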